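The source may report more compounds than this note shows. Statements on the series, on what has been measured and on what is new or still open speak of the compounds shown alone.

Working notes on an in vitro functional assay on cells for agonist activity at Bombesin receptor subtype-3 (Mus musculus), read by luminescence and calcium flux; a higher number here means that more compound is needed for the effect, a lower number that less compound is needed. Compound 1 `O=C(O)c1ccccc1-c1ccc(CCc2ncc(Cc3cccc(Cl)c3)[nH]2)cc1` gives 31 nM, the lowest number of the three measured. Compound 2 `N#Cc1ccc(Cc2cnc(CCc3ccc(-c4ccccc4C(=O)O)cc3)[nH]2)cc1` gives 723 nM, and compound 3 `Cc1ccc(Cc2cnc(CCc3ccc(-c4ccccc4C(=O)O)cc3)[nH]2)cc1` gives 162 nM. The steps of a 23-fold higher number from compound 1 to compound 2 (1.37 log units; beyond the scatter) and a 5.2-fold higher number from compound 1 to compound 3 (0.72 log units; beyond the scatter) show that both exchanges of the 3-chlorophenyl group on a saturated chain carbon bound to an aromatic carbon raised the number, one strongly, one modestly. Compound 4 `O=C(O)c1ccccc1-c1ccc(CCc2ncc(Cc3cccc(F)c3F)[nH]2)cc1` is not yet measured; its change from compound 1 is 2,3-difluorophenyl in place of 3-chlorophenyl on a saturated chain carbon bound to an aromatic carbon. Both measured steps at the same place bear on it and point the same way, so for compound 4 a modest rise beyond the scatter is expected, a 2.6-fold higher number from compound 1 to compound 4 (0.41 log units; beyond the scatter). The estimate for compound 4 is 80 nM, with a range from 25 nM to 260 nM.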

Compound 4, half-maximal effective concentration: 8 nM
Compound 4: middle estimate off by 10-fold (1.00 log units), on the high side; the measured number lies below the stated range.
By their numbers in this assay, from the lowest: compound 4; then compound 1; then compound 3; then compound 2.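

In this assay, among these compounds, 2,3-difluorophenyl is the first replacement of 3-chlorophenyl at this place to lower the number (a 3.9-fold lower number from compound 1 to compound 4 (0.59 log units; beyond the scatter)), so exchanges here do not only raise it. Among the compounds shown here, its steps from the other two aryl groups (a 20-fold lower number from compound 3 to compound 4 (1.31 log units; beyond the scatter); a 90-fold lower number from compound 2 to compound 4 (1.96 log units; beyond the scatter)) show a wider spread at this one place than the earlier compounds did. Nothing at hand accounts for this result.

Open, going by these compounds, is whether one fluorine on the phenyl ring would match two. Also open, on these data alone, is how a methoxy group or an amine on that ring, or a longer chain at the saturated chain carbon, would read.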